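From isopropyl to 4-methylphenyl on the ring nitrogen

A few compounds are considered here, and "the series" means these few. Any claim that something is new, unique, unknown or untested is made for them only; others in the source may bear on it.

In a functional assay on A-375 cells (Homo sapiens) for antiproliferative activity, read by MTT assay, with a stated time of 72 h (on this read-out lower numbers stand for stronger inhibition and higher numbers for weaker inhibition), compound 1 (`COc1ncc(-c2ccc3c(c2)N(c2ccc(C)cc2)C(=O)CO3)cc1NS(=O)(=O)c1ccc(F)cc1`) gives 12900 nM and compound 2 (`COc1ccc(N2C(=O)COc3ccc(-c4cnc(Cl)c(NS(=O)(=O)c5ccc(F)cc5)c4)cc32)cc1`) gives 32700 nM while compound 3 (`CC(C)N1C(=O)COc2ccc(-c3cnc(Cl)c(NS(=O)(=O)c4ccc(F)cc4)c3)cc21`) gives 25500 nM as its value. Compound 3 lies within the scatter of both compound 1 and compound 2, so its place among the three numbers is not firm. Compound 4 (`Cc1ccc(N2C(=O)COc3ccc(-c4cnc(Cl)c(NS(=O)(=O)c5ccc(F)cc5)c4)cc32)cc1`) has not yet been measured. It carries 4-methylphenyl in place of isopropyl on an amide-type nitrogen in a ring. The nearest evidence is a 1.3-fold lower number from compound 2 to compound 3 (0.11 log units; within the scatter) where isopropyl replaces 4-methoxyphenyl on the same nitrogen. That single pair shows no change beyond the scatter, so no step beyond the scatter is expected in this assay for this exchange. Compound 1 also carries 4-methylphenyl but differs elsewhere in the core, so it offers only indirect support. The estimated step is a 1.1-fold lower number from compound 3 to compound 4 (0.04 log units; within the scatter) and it is expected to stay within the scatter. Compound 4 is expected at about 23000 nM with an estimated range from 11000 nM to 46000 nM as its likely span.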

Compound 4, half-maximal inhibitory concentration: 38900 nM
The estimate for compound 4 lay 1.7-fold (0.23 log units) below the measured number; low and high end bracket the measured number.
By their numbers in this assay, from the lowest: compounds 1, 3, 2 and 4 (each within the scatter of the next, the first and the last beyond it).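

In this assay, the ring nitrogen tolerates a switch from isopropyl to 4-methylphenyl, with a 1.5-fold higher number from compound 3 to compound 4 (0.18 log units; within the scatter), so this exchange gives no firm change. Methyl in place of methoxy on an aromatic carbon of the aryl group on that nitrogen adds no firm change either, with a 1.2-fold higher number from compound 2 to compound 4 (0.08 log units; within the scatter). Going by these compounds alone, with 4-methylphenyl held on the nitrogen, the only step beyond the scatter comes from a change elsewhere, chloro in place of methoxy on an aromatic carbon, with a 3.0-fold higher number from compound 1 to compound 4 (0.48 log units; beyond the scatter), and it is modest.

Nothing available bears on the reason for these numbers. From the compounds shown here alone, it remains open whether an amine, a carboxylic acid or a longer chain on the ring nitrogen would move the number beyond the scatter, and whether the chloro and methoxy exchange would give a similar step with isopropyl on that nitrogen.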